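The compounds below may be only part of what the source reports. "The series", "measured", "known", "first", "only" and "open" are said of these compounds alone.

Measured compounds:
Compound 1, `O=C(Nc1cccc(-c2ccsc2)c1)C(Cl)Cl`: in a functional assay on NCI-H460 cells (Homo sapiens) for cytotoxicity, read by MTT assay, with a stated time of 68 h (on this read-out higher numbers stand for weaker inhibition and lower numbers for stronger inhibition), compound 1 reaches only the limit > 50000 nM.
Compound 2, `O=C(Nc1cccc(-c2cccc(Cl)c2)c1)C(Cl)Cl`: in this assay compound 2 reaches only the limit > 50000 nM.
Compound 3, `O=C(Nc1cccc(-c2cccs2)c1)C(Cl)Cl`: in this assay compound 3 reaches only the limit > 50000 nM.

Compound 3 thus stands at the limit of this assay, where all three measured compounds sit (the limit of > 50000 nM in this assay, at which 3 of the 3 values shown sit). Within the data shown here, the only single change among them, a step that the two limits leave unreadable from compound 1 to compound 3, is hidden by two limits and gives no readable size. Compound 4, `O=C(Nc1cccc(-c2ccccc2)c1)C(Cl)Cl`, differs from compound 3 by phenyl in place of thiophen-2-yl on an aromatic carbon. Among the measured compounds shown here, no measured step bears on this change with a readable size, so no shift beyond the scatter can be expected in this assay. Compound 4 is therefore estimated near the limit too, at 60000 nM within 20000 nM to 200000 nM, the expected step being a step that the limit leaves unreadable from compound 3 to compound 4.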

Compound 4, half-maximal inhibitory concentration: 20200 nM
The estimate for compound 4 lay 3.0-fold (0.47 log units) above the measured number; measured number inside the range.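

In this assay, phenyl in place of thiophen-2-yl gives an at least 2.4-fold lower number from compound 3 to compound 4 (0.39 log units; beyond the scatter), and phenyl in place of thiophen-3-yl gives an at least 2.4-fold lower number from compound 1 to compound 4 (0.39 log units; beyond the scatter). Hydrogen in place of chloro on an aromatic carbon gives an at least 2.4-fold lower number from compound 2 to compound 4 (0.39 log units; beyond the scatter). Changes at this position can therefore bring a compound off the assay limit, so each of these sizes is only a minimum: the limit of > 50000 nM in this assay, at which 3 of the 4 values shown sit.

The step between the two thiophene compounds cannot be read. On these data alone, it also remains open how an amine or a carboxylic acid on the phenyl ring would shift the number.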